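The source may report more compounds than this note shows. Statements on the series, on what has been measured and on what is new or still open speak of the compounds shown alone.

In a functional assay on OVCAR-3 cells (Homo sapiens) for antiproliferative activity, read by spectrophotometry, with a stated time of 2 days (a higher number here means a weaker inhibitor of growth, a lower number a stronger inhibitor of growth), compound 1 (`COc1cc(Nc2ncc(C(F)(F)F)c(N3Cc4cccc(N(C)S(C)(=O)=O)c4C3)n2)c(OC)cc1Cl`) gives > 30000 nM as a limit of the assay and not as a number. Compound 2 (`CN(c1cccc2c1CN(c1nc(Nc3ccc(Nc4ccccc4)cc3)ncc1C(F)(F)F)C2)S(C)(=O)=O`) gives > 50000 nM and this too is a limit. Compound 3 (`CN(c1cccc2c1CN(c1nc(Nc3cc(C(F)(F)F)cc(C(F)(F)F)c3)ncc1C(F)(F)F)C2)S(C)(=O)=O`) gives > 30000 nM as a limit again. Compound 1 therefore has no exact place on the scale (the limit of > 30000 nM in this assay, at which 2 of the 3 values shown sit). Compound 4 (`Cc1cc(Cl)ccc1Nc1ncc(C(F)(F)F)c(N2Cc3cccc(N(C)S(C)(=O)=O)c3C2)n1`) keeps the shared core and changes in one place (4-chloro-2-methylphenyl in place of 4-chloro-2,5-dimethoxyphenyl on a nitrogen on an aromatic ring): 4-chloro-2-methylphenyl in place of 4-chloro-2,5-dimethoxyphenyl on a nitrogen on an aromatic ring. Among the compounds with values here, no measured step shows what this swap does. The expectation rests only on compound 1 with its limit of > 30000 nM as the starting point. No change beyond the usual scatter is expected in this assay and the estimated move is a number no higher from compound 1 to compound 4 (the limit leaves the size open) in size. For compound 4 the expected value is 30000 nM with an estimated range from 12000 nM to 60000 nM in this measurement.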

Compound 4, concentration for 50% growth inhibition: > 30000 nM
Compound 4 gave a limit, no number; the forecaster's own chance of this, stated with the estimate: 75%; the middle value sits exactly at the limit.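

Compound 1 and compound 4 each give only a limit of the assay and not a number, so the step between them cannot be read. The compounds shown leave open whether 4-chloro-2-methylphenyl in place of 4-chloro-2,5-dimethoxyphenyl changes growth inhibition at all.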